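Swapping a Heteroaryl Sulfide for an Ethylpiperazine

A few compounds are considered here, and "the series" means these few. Any claim that something is new, unique, unknown or untested is made for them only; others in the source may bear on it.

Compound 2 `Cc1nnc(SCC(=O)Nc2ccc(-c3nc(-c4ccccc4)c(-c4ccccc4)n3C)cc2)s1` stands highest of the two numbers seen so far. In a functional assay on MCF7 cells (Homo sapiens) for cytotoxicity, read by MTT assay, with a stated time of 24 h, tested at 32 ug/mL (a higher number here means a stronger effect of the compound at the concentration tested, a lower number a weaker effect), compound 2 gives 83.4%, while compound 1 `Cn1c(-c2ccc(NC(=O)CSc3nc4cc(Cl)ccc4o3)cc2)nc(-c2ccccc2)c1-c1ccccc1` gives 59.7%. Among the measured compounds shown here, the only measured step, a number 23.7 percentage points higher from compound 1 to compound 2 (beyond the scatter), shows that changing the group on the sulfur at this end of the molecule can move the number by a modest amount. Compound 3 `CCN1CCN(CC(=O)Nc2ccc(-c3nc(-c4ccccc4)c(-c4ccccc4)n3C)cc2)CC1` is not yet measured; it differs from compound 2 by 4-ethylpiperazin-1-yl in place of (5-methyl-1,3,4-thiadiazol-2-yl)sulfanyl on a saturated chain carbon bound to a carbonyl carbon. This removes the sulfur link along with its ring rather than exchanging one ring for another, so the measured step offers only a rough guide, and a change of a modest size in either direction seems possible. Compound 3 is expected to give about 60% in this assay, with a range from 35% to 85%, meaning an expected step of a number 23.4 percentage points lower from compound 2 to compound 3 (beyond the scatter).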

Compound 3, a percentage reported as activity, at one concentration (the size of the read-out at that concentration, not a potency): 38.6%
Beside the measured number, compound 3's estimate is 21.4 percentage points above it; the range from low to high includes it.
By their numbers in this assay, from the lowest: compound 3; then compound 1; then compound 2.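

In this assay, the group on a saturated chain carbon bound to a carbonyl carbon can matter more than the earlier pair suggested: 4-ethylpiperazin-1-yl in place of (5-methyl-1,3,4-thiadiazol-2-yl)sulfanyl gives a number 44.8 percentage points lower from compound 2 to compound 3 (beyond the scatter), a large step. The same exchange made on (5-chloro-1,3-benzoxazol-2-yl)sulfanyl gives a number 21.1 percentage points lower from compound 1 to compound 3 (beyond the scatter), so both sulfur-linked compounds, compound 1 and compound 2, stand above the piperazine compound 3. No measurement at hand explains this fall.

Compound 3 changes the ring and removes the sulfur link at once, so the compounds shown leave open which of the two changes accounts for the lower number. Also open, as far as these compounds go, is how a morpholin-4-yl or a dimethylamino group would read at this place.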